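Fluoro to methoxy on the benzylidene of compound 1

A few compounds are considered here, and "the series" means these few. Any claim that something is new, unique, unknown or untested is made for them only; others in the source may bear on it.

Compound 1 `O=C1/C(=C/c2ccc(F)cc2)CCC/C1=C\c1cccc([N+](=O)[O-])c1` was tested in a functional assay on CCRF-CEM cells (Homo sapiens) for cytotoxicity, with a stated time of 72 h (a higher number here means a weaker inhibitor, a lower number a stronger inhibitor), and gave 5050 nM. Its value is the lowest of the three numbers, but compound 3 `Cc1ccc(/C=C2\CCC/C(=C\c3ccccc3[N+](=O)[O-])C2=O)cc1` gives 6090 nM, which lies within the scatter of it, while compound 2 `COc1cc(/C=C2\CCC/C(=C\c3cccc([N+](=O)[O-])c3)C2=O)cc(OC)c1OC` gives 45200 nM, far beyond the scatter of compound 1. Compound 4 `COc1ccc(/C=C2\CCC/C(=C\c3cccc([N+](=O)[O-])c3)C2=O)cc1` has not yet been measured in this assay. It differs from compound 1 by one change: methoxy in place of fluoro on an aromatic carbon. Going by the values given here, since no pair of measured compounds isolates this change, the step can only be judged loosely; compound 2 carries three methoxy groups and reads well above compound 1, so a rise in the number is expected, of moderate size. Compound 4 is therefore estimated at 9000 nM (range 3000 nM to 30000 nM), a step of a 1.8-fold higher number from compound 1 to compound 4 (0.25 log units; within the scatter) that is expected.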

Compound 4, half-maximal inhibitory concentration: 8220 nM
Estimate against measurement, compound 4: 1.1-fold (0.04 log units) above, and the stated range covers the measured number.
By their numbers in this assay, from the lowest: compounds 1, 3 and 4 (each within the scatter of the next); then compound 2.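

In this assay, going by these compounds alone, compound 4 gives the first reading of a single change at this position: methoxy in place of fluoro, para to a large group, shows a 1.6-fold higher number from compound 1 to compound 4 (0.21 log units; within the scatter) on the core of compound 1. This pair therefore separates 4-fluorophenyl from 4-methoxyphenyl at this position and shows no resolved difference between them. From the compounds shown here alone, whether an amine or a carboxylic acid on this aromatic carbon would also stay within the scatter of compound 1 remains open. No supporting measurement offers an explanation for this result.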